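Benzoxaborole pyrroles in the L929 cytotoxicity screen

The source may report more compounds than this note shows. Statements on the series, on what has been measured and on what is new or still open speak of the compounds shown alone.

Measured compounds:
compound 1 `COc1ccc(Sc2cn(-c3ccc4c(c3)B(O)OC4)c3ccccc23)cc1` — > 10 ug/mL
compound 2 `O=C(c1ccn(-c2ccc3c(c2)B(O)OC3)c1)c1ccc(Cl)cc1Cl` — > 10 ug/mL

The read-out is an ADME assay on L929 cells (Mus musculus) for cytotoxicity, read by resazurin assay, with a stated time of 72 h; a lower number here means a stronger inhibitor, a higher number a weaker inhibitor. Compound 1 gives > 10 ug/mL in this assay, which is a limit of the assay and not a number. Compound 2 likewise gives > 10 ug/mL in this assay, again a limit rather than a number. Compound 2 therefore stands at the limit, and nothing in the two values shown separates it from compound 1; both sit at the limit of > 10 ug/mL in this assay, at which 2 of the 2 values shown sit.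

Compound 3 `Cc1ccccc1C(=O)c1ccn(-c2ccc3c(c2)B(O)OC3)c1` is not yet measured. It differs from compound 2 by 2-methylphenyl in place of 2,4-dichlorophenyl on a carbonyl carbon whose other neighbour is an aromatic carbon. Among the measured compounds shown here, no step between two measured compounds exists in this set, so the size of the change cannot be read from a comparison. The expectation for the step from compound 2 to compound 3 is none beyond the scatter, as a step that the limit leaves unreadable from compound 2 to compound 3. Compound 3 is expected to give about 15 ug/mL, within 7 ug/mL to 40 ug/mL, most likely reported again only as a limit.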

Compound 3, half-maximal inhibitory concentration: > 10 ug/mL
Compound 3 gave a limit, no number (the forecaster's own chance of this, stated with the estimate: 75%); the middle value is on the limit's open side.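

In this assay compound 3 gives > 10 ug/mL, a limit and not a number. Compound 2 also stands at a limit, so no step can be read between compound 2 and compound 3. The compounds shown leave open how much cytotoxicity compound 1, compound 2 and compound 3 each have, and whether 2-methylphenyl in place of 2,4-dichlorophenyl changes it.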